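Three Matching Clearances and One Untested Aryl Swap

This account rests on a few compounds, and the source may have more. Where it says the series, first, only, none or still open, it means among the compounds named here.

In an in vitro ADME assay on microsomes from liver (Homo sapiens) for metabolic stability, in the presence of a further agent that is not named here (a higher number here means faster removal of the compound, a lower number slower removal), compound 1 `CC(C)(CO)CNC(=O)c1cc2cc(C#N)ccc2n1Cc1cccc(OC(F)(F)F)c1` gives 20 mL.min-1.g-1 and compound 2 `CCOc1ccc(OC(F)(F)F)cc1Cn1c(C(=O)NCC(C)(C)CO)cc2cc(C#N)ccc21` gives 20 mL.min-1.g-1 while compound 3 `CC(C)(CO)CNC(=O)c1cc2cc(C#N)ccc2n1Cc1cc(Cl)cc(Cl)c1` gives 22 mL.min-1.g-1 on the same scale. Compound 3 thus sits within the scatter of both other compounds, and the three numbers cannot be ranked.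

The next compound, compound 4 `Cc1ccc(Cl)cc1Cn1c(C(=O)NCC(C)(C)CO)cc2cc(C#N)ccc21`, has not yet been measured. The change leading to it is 5-chloro-2-methylphenyl in place of 3,5-dichlorophenyl on a saturated chain carbon bound to an aromatic nitrogen with 5-chloro-2-methylphenyl in place of 3,5-dichlorophenyl on a saturated chain carbon bound to an aromatic nitrogen.

Among the compounds with values here, no measured pair makes this exact exchange, so the evidence is indirect. Within the data shown here, the one measured single-place change, ethoxy in place of hydrogen on an aromatic carbon, shows no change at the digits printed from compound 1 to compound 2 (within the scatter) in the same part of the molecule. Compound 1 and compound 3 also carry different groups at this place, and their values lie within the scatter of each other. None of the three compounds goes against this flat picture, though three compounds are a thin basis.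

In this assay no step beyond the scatter is therefore expected, and the estimated step is no change at the digits printed from compound 3 to compound 4 (within the scatter) in no preferred direction. For compound 4 the estimated clearance is 22 mL.min-1.g-1 (expected range 13 mL.min-1.g-1 to 38 mL.min-1.g-1).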

Compound 4, intrinsic clearance in microsomes: 23 mL.min-1.g-1
The estimate for compound 4 lay 1.0-fold (0.02 log units) below the measured number, within the range that was stated.
By their numbers in this assay, from the lowest: compounds 1, 2, 3 and 4 (each within the scatter of the next).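

In this assay, within the data shown here, the exchange of 3,5-dichlorophenyl for 5-chloro-2-methylphenyl on a saturated chain carbon bound to an aromatic nitrogen reads a 1.0-fold higher number from compound 3 to compound 4 (0.02 log units; within the scatter) and is the first direct measurement of one whole substituted phenyl group replacing another at this place. The two groups have the same count of heavy atoms and differ in that one chlorine gives way to a carbon, with the substituents named at different ring numbers, and even so the step stays within the scatter. The earlier single-place step, no change at the digits printed from compound 1 to compound 2 (within the scatter) and also within the scatter, concerned only an added ethoxy, so the flat picture now holds for two different kinds of exchange in this part of the molecule, and no compound shown goes against it.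

From the compounds shown here alone, whether a pyridine ring in place of the phenyl ring, or an amine or a carboxylic acid on that ring, would also stay within the scatter remains open. The compounds shown also leave open what a different group in place of the nitrile would do in this assay and whether any exchange at this place can move the number beyond the scatter. No other measurement shown here bears on this result.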